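The source may hold more compounds than are shown below. What is called first, only, known or untested is meant among the compounds shown, and "the series" means these compounds.

Series notes, central read-out a functional assay on the whole organism for antagonist activity, with Rattus norvegicus as the target; on this read-out higher numbers stand for an effect only at larger amounts of compound and lower numbers for an effect already at smaller amounts.

Among the compounds with values here, compound 2 `c1ccc2c(c1)CC2CCCN1CCN(c2cccc3c2OCCO3)CC1` gives 0.16 mg/kg in this assay, the lowest of the two numbers measured so far. Within the data shown here, compound 1 `c1ccc2c(c1)CC2CCCCN1CCN(c2cccc3c2OCCO3)CC1` gives 5 mg/kg in this assay, and the only measured step, a 31-fold lower number from compound 1 to compound 2 (1.49 log units; beyond the scatter), concerns the chain between the group and the ring amine, not the group itself.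

Compound 3 `C1=C(CCN2CCN(c3cccc4c3OCCO4)CC2)Cc2ccccc21` is not yet measured. Its difference from compound 2 is a group of 9 heavy atoms (9 carbon; one five-membered non-aromatic ring of carbon only, one six-membered aromatic ring of carbon only) in place of a group of 9 heavy atoms (9 carbon; one four-membered non-aromatic ring of carbon only, one six-membered aromatic ring of carbon only), on a saturated chain carbon, two bonds along the chain from an amine nitrogen in a ring. Among the measured compounds shown here, this exchange of one group of 9 carbon atoms for another of the same count, with a five-membered non-aromatic ring and one double bond outside aromatic rings entering, has no measured counterpart: the step from compound 1 to compound 2 does not bear on it directly, since it changed the chain rather than the ring portion. Without a comparable step, the expectation is a step of uncertain direction and small to moderate size, which may fall within the scatter; the estimated step is a 2.5-fold higher number from compound 2 to compound 3 (0.40 log units; beyond the scatter). Compound 3 is therefore expected to give about 0.4 mg/kg in this assay, within the range 0.08 mg/kg to 2 mg/kg.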

Compound 3, minimum effective dose: 0.31 mg/kg
Estimate against measurement, compound 3: 1.3-fold (0.11 log units) above; measured number inside the range.
By their numbers in this assay, from the lowest: compounds 2 and 3 (each within the scatter of the next); then compound 1.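

In this assay, the five-membered non-aromatic ring group with its one double bond outside aromatic rings replaces the four-membered ring group on a saturated chain carbon, two bonds along the chain from an amine nitrogen in a ring, and this gives a 1.9-fold higher number from compound 2 to compound 3 (0.29 log units; within the scatter). Within the data shown here, this is the first reading on the ring portion of the group, as the earlier step, a 31-fold lower number from compound 1 to compound 2 (1.49 log units; beyond the scatter), concerned the chain: at this position, the two groups of 9 carbon atoms cannot be told apart in this assay, and the ring portion can change without a step beyond the scatter. No measured evidence gives a reason for this result.

As far as these compounds go, the ring size and the double bond enter together, so their separate contributions remain open, and a five-membered non-aromatic ring without the double bond or a six-membered non-aromatic ring would be needed to separate them. Also open, from the compounds shown here alone, is whether a longer chain on the group from compound 3 would bring a step like the large one seen with the four-membered ring group, and whether a fluorine or methoxy group on the six-membered aromatic ring would leave the number in this range.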